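The compounds below may be only part of what the source reports. "The series", "measured", "known", "first", "only" and "open" are said of these compounds alone.

Compound 1 `Fc1ccccc1C1Cc2nccn2C1` and compound 2 `NC(=O)c1ccccc1C1Cc2nccn2C1` share one core and differ only on the aromatic carbon carrying the substituent; compound 3 `Clc1ccccc1C1Cc2nccn2C1` is the third member of the set. In a functional assay on CHO cells for agonist activity at Alpha-1A adrenergic receptor (Homo sapiens), read by FLIPR and calcium flux (on this read-out higher numbers stand for an effect only at larger amounts of compound and lower numbers for an effect already at smaller amounts), compound 1 gives 42 nM, and compound 2 gives 371 nM. Within the data shown here, compound 2 therefore stands at the highest number of the two measured, with compound 1 as its only neighbour: an 8.8-fold higher number from compound 1 to compound 2 (0.95 log units; beyond the scatter). The change under consideration is chloro in place of carbamoyl on an aromatic carbon. Among the measured compounds shown here, the single measured step that bears on it is an 8.8-fold higher number from compound 1 to compound 2 (0.95 log units; beyond the scatter), which runs in the opposite sense: there a halogen gave way to the carbamoyl, here the carbamoyl gives way to a halogen again. On that basis a downward step of roughly the same size is expected, a 7.4-fold lower number from compound 2 to compound 3 (0.87 log units; beyond the scatter), in this assay. For the measured compounds named here, no measured pair sets chloro against fluoro on this core, so whether chloro lands exactly where compound 1 stands is open, and the range is kept wide. Compound 3 is expected to give 50 nM in this assay, within a range from 15 nM to 170 nM.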

Compound 3, half-maximal effective concentration in the Alpha-1A adrenergic receptor assay: 19 nM
Estimate against measurement, compound 3: 2.6-fold (0.42 log units) above; the range from low to high includes it.
By their numbers in the Alpha-1A adrenergic receptor assay, from the lowest: compound 3; then compound 1; then compound 2.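

In the Alpha-1A adrenergic receptor assay, replacing carbamoyl with chloro on this aromatic carbon gives a 20-fold lower number from compound 2 to compound 3 (1.29 log units; beyond the scatter), a large step that places compound 3, at 19 nM, at the low end of the three compounds, with its steps to both others beyond the scatter. The two halogens also separate in the Alpha-1A adrenergic receptor assay, with a 2.2-fold lower number from compound 1 to compound 3 (0.34 log units; beyond the scatter), so this position distinguishes chloro from fluoro, a modest difference that the earlier pair could not show and that makes carbamoyl the outlier among the three groups. No information is available to explain either step.

From the compounds shown here alone, whether the order seen here extends beyond these three groups stays open, since an amine, a methoxy group, a carboxylic acid or a longer alkyl chain on the same aromatic carbon could fall anywhere relative to them in the Alpha-1A adrenergic receptor assay. In a physicochemical assay for lipophilicity, at pH 7.4 (on this read-out higher numbers stand for higher lipophilicity and lower numbers for lower lipophilicity), compound 3 gives 2.6, while compound 2 has the entry "not determined" (no result reported), so this value stands alone among the compounds shown, and no relation between that read-out and the steps above can be read.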